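The source may report more compounds than this note shows. Statements on the series, on what has been measured and on what is new or still open speak of the compounds shown alone.

Compound 1 `CCNC(=O)c1noc(-c2cc(C(C)C)c(O)cc2O)c1-c1cc(COCC(=O)OC)no1` gives "not determined" (no result reported) here
Compound 2 `CCNC(=O)c1noc(-c2cc(C(C)C)c(O)cc2O)c1-c1cc(CN)no1` gives "not determined" (no result reported) here
Compound 3 `CCNC(=O)c1noc(-c2cc(C(C)C)c(O)cc2O)c1-c1cc(CN2CCCC2)no1` gives 55 nM here

Going by the values given here, these entries come from a functional assay on A2780 cells (Homo sapiens) for inhibition (a lower number here means a stronger inhibitor, a higher number a weaker inhibitor), and compound 3 holds the only number, so it cannot be ranked against anything. Compound 4 `CCNC(=O)c1noc(-c2cc(C(C)C)c(O)cc2O)c1-c1cc(C(=O)O)no1` has carboxy in place of (pyrrolidin-1-yl)methyl on an aromatic carbon. The counted change is carboxy in place of (pyrrolidin-1-yl)methyl on an aromatic carbon and the rest of the shared core stays the same. Among the compounds with values here, no measured step shows what this swap does, so the expectation rests on the structural change alone: weaker inhibition in this assay beyond the scatter. The expected move is a 27-fold higher number from compound 3 to compound 4 (1.44 log units; beyond the scatter) and it carries wide margins. Compound 4 is estimated at 1500 nM with an expected range of 250 nM to 8000 nM for now.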

Compound 4, half-maximal inhibitory concentration: 20000 nM
Estimate against measurement, compound 4: 13-fold (1.12 log units) below; measured number above the stated range.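

Going by these compounds alone, on the aromatic carbon next to the ring nitrogen, carboxy in place of (pyrrolidin-1-yl)methyl gives a 360-fold higher number from compound 3 to compound 4 (2.56 log units; beyond the scatter) in this assay as the first readable comparison. This position is therefore far from indifferent to its substituent, with (pyrrolidin-1-yl)methyl clearly preferred over carboxy. No supporting data explain the size of this step.

One step cannot separate the loss of the ring from the change of group. Going by these compounds, whether an open-chain dimethylaminomethyl group, a piperidin-1-ylmethyl group or a primary amide at this carbon would retain the inhibition of compound 3 remains open.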